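A few compounds are considered here, and "the series" means these few. Any claim that something is new, unique, unknown or untested is made for them only; others in the source may bear on it.

Values in a functional assay on MCF7 cells (Homo sapiens) for cytotoxicity, read by MTT assay, with a stated time of 48 h; a lower number here means a stronger inhibitor, a higher number a weaker inhibitor:
- compound 1 `C/C(=N\NC(=S)Nc1ccc(Cl)cc1)c1ccccn1`: 8.49 nM
- compound 2 `C/C(=N/NC(=S)Nc1ccc(Cl)cc1)c1ccccn1`: 8.49 nM
- compound 3 `C/C(=N/NC(=S)Nc1ccccc1I)c1ccccn1`: 4.1 nM

Compound 1 stands level with compound 2, together the highest of the three numbers, and compound 3 lies lower. Next is compound 4 `C/C(=N\NC(=S)Nc1ccc([N+](=O)[O-])cc1)c1ccccn1`, with nitro in place of chloro on an aromatic carbon, para to a large group: nitro in place of chloro on an aromatic carbon. Among the measured compounds shown here, the one measured step shows no change at the digits printed from compound 1 to compound 2 (within the scatter) and rests on (the fact that compounds 1 and 2 differ only in the configuration as drawn), so it leaves the chloro untouched and gives no size for this change. No step beyond the scatter is therefore expected in this assay. The expected step is a 1.1-fold lower number from compound 1 to compound 4 (0.03 log units; within the scatter). For compound 4 the estimate is 8 nM, with an expected range of 3 nM to 22 nM.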

Compound 4, half-maximal inhibitory concentration: 52 nM
Beside the measured number, compound 4's estimate is 6.5-fold (0.81 log units) below it, outside the stated range (above it).
By their numbers in this assay, from the lowest: compound 3; then compounds 1 and 2 (each within the scatter of the next); then compound 4.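

In this assay the aromatic carbon para to a large group proves sensitive to its substituent, since nitro in place of chloro gives a 6.1-fold higher number from compound 1 to compound 4 (0.79 log units; beyond the scatter) and thus a weaker inhibitor. The earlier compounds shown here held the chloro fixed and showed only a change of drawn configuration with no shift at the digits printed. Nothing at hand explains this step.

From the compounds shown here alone, whether the weakening is particular to nitro remains open, as an amine or a methoxy group on the same carbon would test. Also open, going by these compounds, is whether the drawn double-bond configuration stays without effect when nitro is present.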